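The source may hold more compounds than are shown below. What is called first, only, known or untested is meant among the compounds shown, and "the series" means these compounds.

Measured compounds:
- compound 1, `Cc1cc(=O)oc2c1c(C)nn2CCO`: 100 mg/kg
- compound 2, `CCOC(=O)Cc1nnc2oc(O)cc(C)c1-2`: > 100 mg/kg

Both compounds were tested in a functional assay on the whole organism with Mus musculus as the target, in the writhing test; a higher number here means that more compound is needed for the effect, a lower number that less compound is needed. Within the data shown here, compound 1 gives 100 mg/kg, which is the only measured number in the set. For compound 2 the entry > 100 mg/kg is a limit of the assay rather than a number. Compound 1 therefore stands alone on the numbers shown: of the two values, one is its own number and the other sits at the limit of > 100 mg/kg in this assay, at which 1 of the 2 values shown sits. Among the measured compounds shown here, no two measured compounds differ in only one place, so no measured step is available as a guide.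

Compound 3, `Cc1cc(=O)oc2c1c(C)nn2C`, has not yet been tested. It differs from compound 1 by hydrogen in place of hydroxymethyl on a saturated chain carbon bound to an aromatic nitrogen, so the side chain on the ring nitrogen shrinks from a 2-hydroxyethyl group to a methyl group while the shared core stays the same. For the measured compounds named here, with no measured step to lean on, the expectation is a step from compound 1 to compound 3 of no change at the digits printed from compound 1 to compound 3 (within the scatter), that is, nothing clearly beyond the usual scatter in either direction. Compound 3 is accordingly estimated at 100 mg/kg in this assay, with a range of 40 mg/kg to 250 mg/kg.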

Compound 3, dose for half-maximal effect: 11.6 mg/kg
Beside the measured number, compound 3's estimate is 8.6-fold (0.94 log units) above it, and the stated range ends above it.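

In this assay, the side chain on the aromatic nitrogen proves able to move the result, since replacing the 2-hydroxyethyl group with methyl gives an 8.6-fold lower number from compound 1 to compound 3 (0.94 log units; beyond the scatter). This means that less compound is needed for the effect once the hydroxymethyl part of the chain is gone, and the change is larger than repeat measurements would be expected to produce. The earlier compounds could not show this, as they differ in more than one place, whereas this pair gives the first direct reading of a single change on the shared core, though nothing shown here explains why the number falls.

As far as these compounds go, the two compounds mark only the two ends of this change, so it remains open whether the shorter chain or the missing hydroxyl matters more, and a plain ethyl group or a 2-methoxyethyl group on the same nitrogen would help to separate the two. From the compounds shown here alone, it is also open how a longer chain, an amine or a carboxylic acid at the end of the chain would behave in this assay.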